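The source may report more compounds than this note shows. Statements on the series, on what has been measured and on what is new or still open speak of the compounds shown alone.

Working notes on the series.

Of the compounds shown here, three of this set have been measured in a functional assay on cells (Cancer cell lines, Homo sapiens) for cytotoxicity, with a stated time of 48 h; on this read-out lower numbers stand for stronger inhibition of growth and higher numbers for weaker inhibition of growth. Compound 1 `COc1c(/C=C2/C(=O)Nc3ccccc32)c2ccccc2n1-c1ccccc1` gives 3240 nM and stands lowest of the three numbers. Compound 2 `COc1ccc2c(c1)/C(=C\c1c(Cl)n(C/C=C/c3ccccc3)c3ccccc13)C(=O)N2` gives 21900 nM, a higher number than compound 1 by a margin beyond the usual scatter. Compound 3 `COc1ccc2c(c1)/C(=C\c1c(Cl)n(Cc3cc(OC)c(OC)c(OC)c3)c3cc(C)c(OC)cc13)C(=O)N2` gives 85100 nM, the highest number of the three and again beyond the scatter relative to compound 1. Compounds 2 and 3 share neither the ring substitution pattern nor the side groups of compound 1, so no single-point comparison can be drawn among the measured compounds.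

Compound 4 `COc1c(/C=C2/C(=O)Nc3ccc(Cl)cc32)c2ccccc2n1-c1ccccc1` has not yet been measured. It differs from compound 1 by chloro in place of hydrogen on an aromatic carbon, the carbon being part of a fused system of two rings, meta to a fused ring and para to a fused ring. Among the compounds with values here, no measured pair tests this change, so the expected step rests only on the small size of the substitution. The step from compound 1 to compound 4 is expected to be small, a 1.3-fold lower number from compound 1 to compound 4 (0.11 log units; within the scatter), most likely not beyond the scatter, with a slight lean toward a lower number. Compound 4 is accordingly estimated at 2500 nM in this assay, within a range from 1000 nM to 7000 nM.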

Compound 4, concentration for total growth inhibition: 25700 nM
For compound 4 the middle estimate is 10-fold (1.01 log units) below the measured one; measured number outside the range, above it.
By their numbers in this assay, from the lowest: compound 1; then compounds 2 and 4 (each within the scatter of the next); then compound 3.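

In this assay, within the data shown here, the only single-place change that can be read is chloro in place of hydrogen on an aromatic carbon, meta to a fused ring and para to a fused ring, with a 7.9-fold higher number from compound 1 to compound 4 (0.90 log units; beyond the scatter) as its step. This shows that at this carbon of the core of compound 1, one added chlorine atom is enough to move the number beyond the scatter, toward weaker inhibition of growth, which compounds differing in several places could not show. The step gives a size and a direction at this one carbon, while no measurement at hand bears on what lies behind it.

Going by these compounds, it remains open whether fluoro, a nitrile or an amine on the same aromatic carbon would give a step of similar size and direction, and whether chloro on another carbon of that ring would do the same. On these data alone, it also remains open whether the chloro step would hold with other side groups on the core, as compounds 2 and 3 differ from compound 1 in more than one place.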